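Chloro on the fused ring of a vasopressin V2 ligand

A few compounds are considered here, and "the series" means these few. Any claim that something is new, unique, unknown or untested is made for them only; others in the source may bear on it.

Compounds measured so far:
compound 1, `CN(C)c1ccc(C(=O)N2CCCCc3cc(Cl)ccc32)c(Cl)c1`, with 13 nM in an assay on HeLa cells for binding affinity to Vasopressin V2 receptor (Homo sapiens); on this read-out lower numbers stand for stronger inhibition and higher numbers for weaker inhibition
compound 2, `O=C(c1ccc(N2CCCC2)cc1Cl)N1CCCCc2ccccc21`, with 9 nM in this assay

Of the two numbers, compound 2 gives the smaller one, but the gap to compound 1 lies within the usual scatter, so the two cannot be told apart on this evidence.

Compound 3, `O=C(c1ccc(N2CCCC2)cc1Cl)N1CCCCc2cc(Cl)ccc21`, has not yet been measured. It differs from compound 2 in one place: chloro in place of hydrogen on an aromatic carbon. Compound 1 already carries a chloro at that point of its core and still sits within the scatter of compound 2, so nothing here suggests a large effect of this change.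

The step from compound 2 to compound 3 in this assay is therefore expected to be small, a 1.1-fold lower number from compound 2 to compound 3 (0.05 log units; within the scatter), possibly none beyond the scatter. Compound 3 is estimated at 8 nM, with a range from 3 nM to 25 nM.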

Compound 3, half-maximal inhibitory concentration: 16 nM
Estimate against measurement, compound 3: 2.0-fold (0.30 log units) below; the range from low to high includes it.
By their numbers in this assay, from the lowest: compounds 2, 1 and 3 (each within the scatter of the next).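

Chloro in place of hydrogen on this aromatic carbon gives a 1.8-fold higher number from compound 2 to compound 3 (0.25 log units; within the scatter) in this assay and thus supplies the direct pair that compound 1 could not: with pyrrolidin-1-yl held constant, compound 2 and compound 3 cannot be told apart. With the chloro present on the core, pyrrolidin-1-yl in place of dimethylamino gives a 1.2-fold higher number from compound 1 to compound 3 (0.09 log units; within the scatter) and leaves those two compounds equally indistinguishable. Nothing available offers an explanation for either step.

From the compounds shown here alone, whether a fluoro, a methoxy or a carboxylic acid on this aromatic carbon would give a step beyond the scatter remains open. So does whether chloro here would behave the same way alongside another amine on the benzoyl ring, such as morpholin-4-yl or piperidin-1-yl.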